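This account rests on a few compounds, and the source may have more. Where it says the series, first, only, none or still open, it means among the compounds named here.

Measured compounds:

Compound 1 `CCc1cc2ccccc2nc1-c1cc(-c2ccc(F)cc2)no1`: in a functional assay on COLO 205 cells (Homo sapiens) for inhibition, read by MTT assay, with a stated time of 24 h (on this read-out lower numbers stand for stronger inhibition and higher numbers for weaker inhibition), compound 1 gives > 100000 nM, which is a limit of the assay rather than a number.
Compound 2 `CCCc1cc2ccccc2nc1-c1cc(-c2ccc(F)cc2)no1`: compound 2 gives 50300 nM.
Compound 3 `CCCc1cc2ccccc2nc1-c1cc(-c2ccc(C)cc2)no1`: compound 3 gives > 100000 nM, again a limit of the assay.

Within the data shown here, two of the three values sit at the same limit (the limit of > 100000 nM in this assay, at which 2 of the 3 values shown sit), so the series is read mostly through its one numbered value. As far as these compounds go, compound 1 and compound 2 share a core and differ by methyl in place of hydrogen on a saturated chain carbon, two bonds along the chain from an aromatic carbon; this step gives an at least 1.9-fold lower number from compound 1 to compound 2 (0.29 log units; that floor lies within the scatter), and the true size of that step is unknown because compound 1 sits at the limit of > 100000 nM in this assay, at which 2 of the 3 values shown sit. Compound 2 and compound 3 differ by an at least 1.9-fold higher number from compound 2 to compound 3 (0.29 log units; that floor lies within the scatter), so the methyl-bearing aryl compound falls back to the limit.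

The unmeasured compound 4 `CCCCc1cc2ccccc2nc1-c1cc(-c2ccc(C)cc2)no1` stands to compound 3 as compound 2 stands to compound 1, by methyl in place of hydrogen on a saturated chain carbon, three bonds along the chain from an aromatic carbon. The difference between the core of compound 3 and the core of compound 1 is not broken down here. The place is not identical: in the earlier pair the new methyl sits two bonds along the chain from an aromatic carbon, in the new pair three bonds along, so this is the same kind of change rather than the same change.

Since compound 3 gives only > 100000 nM and the earlier pair moved only an at least 1.9-fold lower number from compound 1 to compound 2 (0.29 log units; that floor lies within the scatter), compound 4 is expected to move by roughly an at least 1.1-fold lower number from compound 3 to compound 4 (0.04 log units; that floor lies within the scatter) in this assay. Compound 4 is therefore estimated at about 90000 nM, between 30000 nM and 300000 nM, with a real chance that the assay again returns only a limit.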

Compound 4, half-maximal inhibitory concentration: > 100000 nM
Compound 4 ended at the assay's limit; the forecaster's own chance of this, stated with the estimate: 60%; middle value at least 1.1-fold (0.04 log units) from the limit.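

Compound 3 and compound 4 both return a limit of the assay rather than a number in this assay, so no step between them can be read: the limit of > 100000 nM in this assay, at which 3 of the 4 values shown sit.

The compounds shown leave open whether going from propyl to butyl changes inhibition at all when methyl stands in place of fluoro on the aromatic carbon, and how far the true values of these compounds lie from that limit.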